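Methyl for trifluoromethyl on the aryl ring of compound 1

The compounds below may be only part of what the source reports. "The series", "measured", "known", "first", "only" and "open" are said of these compounds alone.

Measured so far:
compound 1 `CC#CC(CC(=O)O)c1ccc(OCc2ccc3nc(-c4ccc(C(F)(F)F)cc4)cn3c2)cc1` — 558 nM
compound 2 `CC#CC(CC(=O)O)c1ccc(OCc2ccn3cc(-c4ccc(C)cc4C)nc3c2)cc1` — 503 nM
compound 3 `CC#CC(CC(=O)O)c1ccc(OCc2ccn3cc(-c4ccc(C)cc4)nc3c2)cc1` — 618 nM

In an assay on isolated protein for agonist activity at Free fatty acid receptor 1 (Homo sapiens) (on this read-out higher numbers stand for an effect only at larger amounts of compound and lower numbers for an effect already at smaller amounts), compound 1 gives 558 nM. Compound 3 with 618 nM is the nearest of the other two and compound 2 with 503 nM the furthest, yet both lie within the scatter of compound 1, so the three measured numbers cannot be told apart.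

Compound 4 `CC#CC(CC(=O)O)c1ccc(OCc2ccc3nc(-c4ccc(C)cc4)cn3c2)cc1` has not been measured. It differs from compound 1 in one place: methyl in place of trifluoromethyl on an aromatic carbon. Going by the values given here, no measured step exchanges trifluoromethyl for methyl, so nothing bears directly on this change. Among the compounds with values here, the only measured step on an aromatic carbon of the same kind of ring is a 1.2-fold higher number from compound 2 to compound 3 (0.09 log units; within the scatter), which removes a methyl and stays within the scatter. Across compounds 1, 2 and 3 different aryl substituents have left the numbers within the scatter of one another.

For compound 4 the expected step is therefore a 1.1-fold higher number from compound 1 to compound 4 (0.03 log units; within the scatter), none beyond the scatter in either direction. The estimate for compound 4 is 600 nM, with a range from 300 nM to 1200 nM.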

Compound 4, half-maximal effective concentration: 507 nM
Compound 4: middle estimate off by 1.2-fold (0.07 log units), on the high side; the range from low to high includes it.
By their numbers in this assay, from the lowest: compounds 2, 4, 1 and 3 (each within the scatter of the next).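

In this assay, going by these compounds alone, the change from 4-(trifluoromethyl)phenyl to 4-methylphenyl gives a 1.1-fold lower number from compound 1 to compound 4 (0.04 log units; within the scatter), the first direct reading of this exchange. On the core of compound 1, trifluoromethyl and methyl therefore cannot be told apart at this aromatic carbon on this read-out, whereas the earlier step concerned only the removal of a methyl on the core of compound 2. Nothing available accounts for the two groups reading alike.

On these data alone, whether an amine, a carboxylic acid or a longer alkyl chain at this position would move the number beyond the scatter remains open. Equally open, as far as these compounds go, is whether the same exchange of trifluoromethyl for methyl would read alike on the core of compound 3.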